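The source may hold more compounds than are shown below. What is called first, only, known or untested is meant among the compounds shown, and "the series" means these compounds.

Of the compounds shown here, three sharing one core have been measured in a functional assay on HT-29 cells (Homo sapiens) for inhibition, read by sulforhodamine B assay, with a stated time of 72 h; on this read-out lower numbers stand for stronger inhibition and higher numbers for weaker inhibition. There, compound 1 `CCSc1ccc(C2C(Oc3ccccc3)C(=O)N2c2cc(OC)c(OC)c(OC)c2)cc1` gives 632 nM, compound 2 `COc1ccc(C2C(O)C(=O)N2c2cc(OC)c(OC)c(OC)c2)cc1O` gives 463 nM and compound 3 `COc1ccc(C2C(C3CC3)C(=O)N2c2cc(OC)c(OC)c(OC)c2)cc1` gives 107 nM. Compound 2 is therefore second highest of the three numbers: it lies within the scatter of compound 1, while compound 3 reads lower by more than the scatter. Within the data shown here, no two measured compounds differ in a single place, so the data offer no direct measure of the next change. Compound 4 `COc1cc(N2C(=O)C(O)C2c2ccc(SC)cc2)cc(OC)c1OC` departs from compound 2 in one substituent: 4-(methylsulfanyl)phenyl in place of 3-hydroxy-4-methoxyphenyl on a saturated ring carbon. This places 4-(methylsulfanyl)phenyl in place of 3-hydroxy-4-methoxyphenyl on a saturated ring carbon, next to the ring nitrogen and next to the ring atom that bears a hydroxy group. The expected shift is modest, towards a lower number, and may stay within the scatter, with compound 3 at 107 nM marking the low end of the numbers seen so far. The estimated step is a 1.5-fold lower number from compound 2 to compound 4 (0.19 log units; within the scatter). Compound 4 is estimated at 300 nM, with an expected range from 90 nM to 1000 nM.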

Compound 4, half-maximal inhibitory concentration: 15 nM
Compound 4: the middle estimate sits 20-fold (1.30 log units) above what was measured; measured number outside the range, below it.
By their numbers in this assay, from the lowest: compound 4; then compound 3; then compounds 2 and 1 (each within the scatter of the next).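

In this assay, among these compounds, putting 4-(methylsulfanyl)phenyl in place of 3-hydroxy-4-methoxyphenyl gives a 31-fold lower number from compound 2 to compound 4 (1.49 log units; beyond the scatter), the first single-place comparison in this set, and it shows that the group on this saturated ring carbon, next to the ring nitrogen, can move the number a long way. The exchange is a composite one, since the entering group has 0 hydrogen-bond donors and 1 acceptor, against 1 donor and 2 acceptors in the group that leaves, and sulfur enters as both oxygens leave. Nothing available here bears on the reason for this step.

The compounds shown leave open which part of the exchange carries the step, and how an amine or a sulfone would read in place of the methylsulfanyl group. Also open, going by these compounds, is whether the step would hold with the phenoxy group of compound 1 or the cyclopropyl group of compound 3 in place of the hydroxy group.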